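From pyridin-2-yl to 1,3,4-thiadiazol-2-yl on sulfur

The source may hold more compounds than are shown below. What is called first, only, known or untested is meant among the compounds shown, and "the series" means these compounds.

In a functional assay on PC-3 cells (Homo sapiens) for antiproliferative activity, read by MTT assay, with a stated time of 72 h (on this read-out lower numbers stand for stronger inhibition and higher numbers for weaker inhibition), compound 1 `C#CCSc1nc(Sc2nc(C)c(C)s2)c(C#N)c(-c2cc(OC)c(OC)c(OC)c2)n1` gives > 20000 nM, which is a limit. Compound 2 `C#CCSc1nc(Sc2ccccn2)c(C#N)c(-c2cc(OC)c(OC)c(OC)c2)n1` gives > 10000 nM, also a limit, so compound 2 has no numerical value. Among the compounds with values here, the only measured step is a step that the two limits leave unreadable from compound 1 to compound 2. Within the data shown here, compound 3 `C#CCSc1nc(Sc2nccs2)c(C#N)c(-c2ccc(Br)cc2)n1` gives 8530 nM, but it differs from compound 2 in more than one place and gives no clean step.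

Compound 4 `C#CCSc1nc(Sc2nncs2)c(C#N)c(-c2cc(OC)c(OC)c(OC)c2)n1` follows from 1,3,4-thiadiazol-2-yl in place of pyridin-2-yl on a sulfur. Among the measured compounds shown here, no measured step gives a size for this change, so no clear gain is expected in this assay, and the direction remains open. The expected step is a step that the limit leaves unreadable from compound 2 to compound 4. For compound 4 the estimate is 15000 nM, with an expected range of 6000 nM to 40000 nM.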

Compound 4, half-maximal inhibitory concentration: 10300 nM
Compound 4: the middle estimate sits 1.5-fold (0.16 log units) above what was measured; the measured number falls inside the stated range.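

With 1,3,4-thiadiazol-2-yl on the sulfur, the core of compound 1 gives a number rather than a limit in this assay. Against 4,5-dimethyl-1,3-thiazol-2-yl, the change reads as an at least 1.9-fold lower number from compound 1 to compound 4 (0.28 log units; that floor lies within the scatter), so no real gain can be claimed. The step from compound 2 to compound 4 cannot be read because compound 2 has only a limit: the limit of > 10000 nM in this assay, at which 1 of the 4 values shown sits.

Open, as far as these compounds go, is what an amine or a carboxylic acid on a longer chain at this sulfur would give in this assay. Also open, from the compounds shown here alone, is whether any group here clearly lowers the number set by compound 4.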